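The source may report more compounds than this note shows. Statements on the series, on what has been measured and on what is new or still open speak of the compounds shown alone.

Compound 1 `CC(C)c1ccc(NC(=O)N[C@H](C)c2ccccc2)cc1` gives 79%
Compound 2 `CC(C)c1ccc(NC(=O)N[C@@H](C)c2ccccc2)cc1` gives 96%
Compound 3 `CC(=O)c1ccccc1NC(=O)N[C@H](C)c1ccccc1` gives 95%

In an ADME assay on the whole organism with Oryza sativa as the target, tested at 1 uM (on this read-out lower numbers stand for a stronger effect and higher numbers for a weaker effect at the one concentration tested), compound 1 stands lowest of the three numbers, and so shows the strongest effect among them; compound 3 comes nearest to it, and the number for compound 2 lies furthest away. For the measured compounds named here, the one step measured between compounds that differ in a single place is a number 17 percentage points higher from compound 1 to compound 2 (beyond the scatter), a modest rise that goes with the fact that compounds 1 and 2 differ only in the configuration as drawn.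

Compound 4 `C[C@@H](NC(=O)Nc1ccc(Br)cc1)c1ccccc1` differs from compound 1 by bromo in place of isopropyl on an aromatic carbon. Going by the values given here, none of the measured steps bears on this exchange: the step from compound 1 to compound 2 concerns configuration alone and says nothing about swapping one substituent for another on the aromatic ring, and compound 3 carries a different substitution pattern altogether, with no single-place link to compound 1. Among the compounds with values here, with no comparable step to lean on, the most defensible expectation in this assay is a step of no particular direction, and a number that may well fall within the scatter of compound 1, though the range must be kept wide.

Compound 4 is therefore expected to give about 85%, most likely between 65% and 100%. The expected step is a number 6 percentage points higher from compound 1 to compound 4 (within the scatter).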

Compound 4, a percentage reported as activity, at one concentration (the size of the read-out at that concentration, not a potency): 95%
Estimate against measurement, compound 4: 10 percentage points below, within the range that was stated.
By their numbers in this assay, from the lowest: compound 1; then compounds 3, 4 and 2 (each within the scatter of the next).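

In this assay, the aromatic carbon para to a large group proves sensitive to what it carries, with bromo in place of isopropyl giving a number 16 percentage points higher from compound 1 to compound 4 (beyond the scatter). For the compounds shown here, the earlier compounds showed a single-place step only for configuration at the stereocentre, so this is the first sign that the substituent on the ring also moves the read-out, here towards a weaker effect at the one concentration tested. Nothing available on these compounds bears on why this exchange moves the number, as the only fact at hand concerns configuration and not a ring substituent.

On these data alone, it remains open whether the weaker effect follows from the loss of isopropyl in particular or would appear with any other replacement on this aromatic carbon, such as a tert-butyl group, a methoxy group, a chlorine or an amine. Also open, as far as these compounds go, is whether the same exchange would move the number at all in the configuration of compound 2, which stands at 96% with isopropyl in place.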